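Thioether Analogue of a Diaminoquinoxaline Cytotoxicity Series

The compounds below may be only part of what the source reports. "The series", "measured", "known", "first", "only" and "open" are said of these compounds alone.

Measured so far:
compound 1, `Nc1cc(N)c2nc(-c3ccccc3)c(Oc3ccc(F)cc3)nc2c1`: 77600 nM
compound 2, `CCOC(=O)[C@H](CCC(=O)O)NC(=O)c1ccc(Oc2nc3cc(N)cc(N)c3nc2-c2ccccc2)cc1`: 60300 nM

Of the compounds shown here, two share a core and have been tested in a functional assay on NCI-H23 cells (Homo sapiens) for inhibition, read by sulforhodamine B assay, with a stated time of 48 h; on this read-out higher numbers stand for lower toxicity in this test and lower numbers for higher toxicity in this test. Compound 1 gives 77600 nM in this assay, and compound 2 gives 60300 nM. Compound 1 carries the larger figure of the two, but the gap to compound 2 falls within the usual scatter, so the two cannot be told apart on these numbers, and nothing about the effect of a change at the core can yet be drawn from them.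

Compound 3, `COc1ccc(Sc2nc3cc(N)cc(N)c3nc2-c2ccccc2)cc1`, is not yet measured in this assay. It differs from compound 1 in one place: (4-methoxyphenyl)sulfanyl in place of 4-fluorophenoxy on an aromatic carbon. Within the data shown here, no step between measured compounds shows what such an exchange does here, so the expectation rests on the closeness of compound 1 and compound 2 alone. Compound 3 is expected to give about 60000 nM in this assay, with a range from 20000 nM to 180000 nM. The step of a 1.3-fold lower number from compound 1 to compound 3 (0.11 log units; within the scatter) is expected to stay within the scatter, in no clear direction.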

Compound 3, concentration lethal to 50% of the cells: < 100000 nM
Compound 3: only a limit was reported; the forecaster's own chance of this, stated with the estimate: 25%; the middle value does not contradict the limit.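

In this assay compound 3 is reported with < 100000 nM and this is a limit, not a number. Among these compounds, no step from compound 1 to compound 3 can be read from it: the limit of < 100000 nM in this assay, at which 1 of the 3 values shown sits.

The compounds shown leave open what (4-methoxyphenyl)sulfanyl in place of 4-fluorophenoxy on an aromatic carbon does to the read-out, in size or in direction.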